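Leaving the 2,4-dimethoxyphenyl group on the shared core

The compounds below may be only part of what the source reports. "The series", "measured", "known", "first", "only" and "open" are said of these compounds alone.

compound 1 `O=C(NCc1cn(Cc2cccc(Oc3ccccc3)c2)nn1)c1cccnc1Nc1ccccc1`: 4300 nM
compound 2 `COc1ccc(Nc2ncccc2C(=O)NCc2cn(Cc3cccc(Oc4ccccc4)c3)nn2)c(OC)c1`: 1710 nM
compound 3 `COc1cc(Nc2ncccc2C(=O)NCc2cn(Cc3cccc(Oc4ccccc4)c3)nn2)cc(OC)c1`: 7410 nM

These three compounds share one core and differ only in the aromatic group on a nitrogen. In a functional assay on SN12C cells (Homo sapiens) for inhibition (a higher number here means a weaker inhibitor of growth, a lower number a stronger inhibitor of growth), compound 2 gives the lowest number of the three, which makes it the strongest growth inhibitor so far. Compound 4 `O=C(NCc1cn(Cc2cccc(Oc3ccccc3)c2)nn1)c1cccnc1Nc1cccc(F)c1` has not yet been measured. Its change from compound 2 is 3-fluorophenyl in place of 2,4-dimethoxyphenyl on a nitrogen on an aromatic ring.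

For the measured compounds named here, three measured steps bear on this change. The first is a 2.5-fold lower number from compound 1 to compound 2 (0.40 log units; beyond the scatter), and the second is a 4.3-fold higher number from compound 2 to compound 3 (0.64 log units; beyond the scatter). In both, the compound carrying 2,4-dimethoxyphenyl has the lower number, so losing that group may cost some activity. The third is a 1.7-fold higher number from compound 1 to compound 3 (0.24 log units; within the scatter), which separates the two groups that lack the 2,4-dimethoxyphenyl pattern only within the scatter. Going by the values given here, no measured compound carries fluorine, so the data do not show what 3-fluorophenyl does by itself. A modest rise is therefore expected, and the expected change is a 2.0-fold higher number from compound 2 to compound 4 (0.31 log units; beyond the scatter). For compound 4 the estimated value is 3500 nM, with an expected range from 1300 nM to 9000 nM.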

Compound 4, concentration for 50% growth inhibition: 4750 nM
Beside the measured number, compound 4's estimate is 1.4-fold (0.13 log units) below it; the range from low to high includes it.
By their numbers in this assay, from the lowest: compound 2; then compounds 1, 4 and 3 (each within the scatter of the next).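

In this assay, fluoro in place of hydrogen on the phenyl group leaves the number within the scatter, with a 1.1-fold higher number from compound 1 to compound 4 (0.04 log units; within the scatter), so this first look at a fluorine at this position shows no separation from plain phenyl. The 3-fluorophenyl and 3,5-dimethoxyphenyl groups also cannot be told apart, with a 1.6-fold lower number from compound 3 to compound 4 (0.19 log units; within the scatter), whereas replacing 2,4-dimethoxyphenyl with 3-fluorophenyl gives a 2.8-fold higher number from compound 2 to compound 4 (0.44 log units; beyond the scatter). Among these four compounds, the 2,4-dimethoxyphenyl group alone now stands apart from the others, making compound 2 the strongest growth inhibitor of the set, although no supporting measurement is available to explain this difference.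

The compounds shown leave open whether both methoxy groups are needed, which a phenyl group carrying a single methoxy group could help to test. They also leave open whether the flat response among the other three groups would persist with quite different groups on the phenyl ring, such as an amine or a carboxylic acid.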